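A few compounds are considered here, and "the series" means these few. Any claim that something is new, unique, unknown or untested is made for them only; others in the source may bear on it.

Compound 1 `Cc1ccc(OCC(=O)N(Cc2cccs2)c2ccnn2C)cc1` is the reference point for this short series. In an assay on HEK293 cells for agonist activity at transient receptor potential cation channel subfamily M member 8 (Homo sapiens), read by fluorescence and calcium flux, with a stated time of 15 min (a lower number here means that less compound is needed, a higher number that more compound is needed for the effect), compound 1 gives 422 nM, the lowest of the two numbers recorded so far. Among the compounds with values here, the only other measured member, compound 2 `CCN(Cc1cccs1)C(=O)C[C@H](O)c1ccccc1`, gives in this assay a value of 52000 nM, a gap that lies far beyond the usual scatter; since compound 2 differs from compound 1 in more than one place, the two values say only that compound 1 is by far the more potent of the pair. The step examined here leads from compound 1 to the not yet measured compound 3 `CCC(C)N(Cc1cccs1)C(=O)COc1ccc(C)cc1`, where the change is sec-butyl in place of 1-methyl-1H-pyrazol-5-yl on an amide-type nitrogen. No single-point comparison between measured compounds is available to calibrate this change. In this assay the expectation is for a step from compound 1 to compound 3 of a 5.9-fold higher number from compound 1 to compound 3 (0.77 log units; beyond the scatter), a loss beyond the scatter, in the direction of more compound being needed. For compound 3 the estimated value in this assay is 2500 nM, with a plausible range from 500 nM to 12000 nM.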

Compound 3, half-maximal effective concentration: 2000 nM
Compound 3: the middle estimate sits 1.3-fold (0.10 log units) above what was measured; the measured number falls inside the stated range.
By their numbers in this assay, from the lowest: compound 1; then compound 3; then compound 2.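

Within the data shown here, replacing the 1-methyl-1H-pyrazol-5-yl on the amide-type nitrogen with sec-butyl gives, in this assay, a 4.7-fold higher number from compound 1 to compound 3 (0.68 log units; beyond the scatter), the first comparison that isolates a single place. The result shows that the five-membered aromatic ring is not required for a measurable response: with a sec-butyl group that has no ring and no hydrogen-bond acceptors in that place, compound 3 still gives 2000 nM, although more compound is needed than for compound 1. Nothing measured alongside these values accounts for the size or direction of this step.

Among these compounds, because the change removes the ring and its nitrogen atoms together and also replaces the methyl-bearing ring with a branched chain, the single step cannot show which of these features matters. On these data alone, a phenyl or cyclopentyl group at the same nitrogen would separate the ring from its nitrogen atoms, while an n-butyl chain would test the branching of sec-butyl, and how either would compare with compound 1 remains open.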